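This account rests on a few compounds, and the source may have more. Where it says the series, first, only, none or still open, it means among the compounds named here.

Measured compounds:
- compound 1 `Cc1cc(C)c2cccc(OCc3c(Cl)ccc(S(=O)(=O)NC4(C(=O)N5CCN(C(=O)[C@H](CCCCN)[N+](C)(C)C)CC5)CCCC4)c3Cl)c2n1`: in an assay on isolated protein for binding affinity to B1 bradykinin receptor (Homo sapiens) (on this read-out lower numbers stand for stronger inhibition and higher numbers for weaker inhibition), compound 1 gives < 10000 nM; this is a limit of the assay, not a number.
- compound 2 `Cc1cc(C)c2cccc(OCc3c(Cl)ccc(S(=O)(=O)NC4(C(=O)N5CCN(C(=O)CCC[N+](C)(C)C)CC5)CCCC4)c3Cl)c2n1`: in this assay compound 2 gives < 10000 nM; again a limit of the assay, not a number.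

Compound 2 thus stands only at the limit; no numerical position within the series can be read for it. Among the measured compounds shown here, the one step between measured compounds, a step that the two limits leave unreadable from compound 1 to compound 2, is left unreadable because of the limit of < 10000 nM in this assay, at which 2 of the 2 values shown sit, so the exchange of the side chain on the carbonyl carbon cannot be sized.

Compound 3 `Cc1cc(C)c2cccc(OCc3c(Cl)ccc(S(=O)(=O)NC4(C(=O)N5CCN(C(=O)[C@@H](N)CC[N+](C)(C)C)CC5)CCCC4)c3Cl)c2n1` is not yet measured. It differs from compound 2 by amino in place of hydrogen on a saturated chain carbon bound to a carbonyl carbon and a saturated chain carbon. For the measured compounds named here, no measured step bears on this change; the only step known, between compound 1 and compound 2, sits wholly at the limit and gives neither size nor direction. The expected step that the limit leaves unreadable from compound 2 to compound 3 is therefore set at none beyond the scatter, with wide uncertainty.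

For compound 3 the estimate in this assay is 1000 nM, within 30 nM to 10000 nM, and a further limit report is considered likely.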

Compound 3, inhibition constant: < 10000 nM
Compound 3 gave a limit, no number (the forecaster's own chance of this, stated with the estimate: 60%); the middle value lies beyond the limit too.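

No new step can be read among compound 1, compound 2 and compound 3, because all three give a limit, not a number: the limit of < 10000 nM in this assay, at which 3 of the 3 values shown sit.
In this assay the compounds shown leave open the numerical value of each compound, and so whether amino in place of hydrogen, or either exchange of the group on the carbonyl carbon, shifts the read-out at all.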